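The source may hold more compounds than are shown below. What is called first, only, known or untested is meant among the compounds shown, and "the series" means these compounds.

In a functional assay on MCF7 cells (Homo sapiens) for cytotoxicity, read by MTT assay, with a stated time of 72 h (on this read-out higher numbers stand for weaker inhibition and lower numbers for stronger inhibition), compound 1 (`COc1cccc(/C=C2\CCC/C(=C\c3ccccc3Cl)C2=O)c1OC`) gives 11300 nM while compound 2 (`COc1cccc(/C=C2\CCC/C(=C\c3cccc(Br)c3)C2=O)c1OC`) gives 11700 nM and compound 3 (`COc1cccc(/C=C2\CCC/C(=C\c3cccc(O)c3)C2=O)c1OC`) gives 8800 nM with all three numbers within the scatter of one another. Compound 3 therefore stands level with the other two on these numbers.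

Compound 4 (`COc1cccc(/C=C2\CCC/C(=C\c3ccc(O)c(Cl)c3)C2=O)c1OC`) is the next case. It differs from compound 3 (3-chloro-4-hydroxyphenyl in place of 3-hydroxyphenyl on a double-bonded chain carbon bound to a double-bonded ring carbon) with 3-chloro-4-hydroxyphenyl in place of 3-hydroxyphenyl on a double-bonded chain carbon bound to a double-bonded ring carbon.

Three measured steps change the group at this same place, and none leaves the scatter (a 1.0-fold higher number from compound 1 to compound 2 (0.02 log units; within the scatter); a 1.3-fold lower number from compound 1 to compound 3 (0.11 log units; within the scatter); a 1.3-fold lower number from compound 2 to compound 3 (0.12 log units; within the scatter)). Chloro, bromo and hydroxy have each been seen on the phenyl group, but no measured compound carries chloro and hydroxy together, so this combination remains untested. On this limited evidence, no step beyond the scatter is expected in this assay and no direction can be favoured. The expected size is small (a 1.1-fold lower number from compound 3 to compound 4 (0.04 log units; within the scatter)). For compound 4 the estimated value is 8000 nM (estimated range 4000 nM to 16000 nM).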

Compound 4, half-maximal inhibitory concentration: 16400 nM
Beside the measured number, compound 4's estimate is 2.1-fold (0.31 log units) below it; measured number outside the range, above it.
By their numbers in this assay, from the lowest: compounds 3, 1, 2 and 4 (each within the scatter of the next).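

In this assay, all three new steps stay within the scatter (a 1.9-fold higher number from compound 3 to compound 4 (0.27 log units; within the scatter); a 1.4-fold higher number from compound 2 to compound 4 (0.15 log units; within the scatter); a 1.5-fold higher number from compound 1 to compound 4 (0.16 log units; within the scatter)). Chloro and hydroxy together on the phenyl group therefore leave compound 4 level with compounds 1, 2 and 3, so on a double-bonded chain carbon bound to a double-bonded ring carbon, this series shows no separation among 3-chloro-4-hydroxyphenyl, 3-hydroxyphenyl, 3-bromophenyl and 2-chlorophenyl. The data at hand offer no explanation for the size of any of these steps.

The compounds shown leave open whether an amine or a carboxylic acid on the phenyl group, or a longer chain carrying that ring, would give a step beyond the scatter at this place. They also leave open how 3-chloro-4-hydroxyphenyl compares with 4-hydroxyphenyl, and whether changes elsewhere on the shared core would separate the compounds in this assay.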